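The compounds below may be only part of what the source reports. "The series", "measured", "known", "first", "only" and "open" are said of these compounds alone.

Measured compounds:

Compound 1, `O=C1COc2ccc(-c3cnc(Cl)c(NS(=O)(=O)c4ccc(F)cc4)c3)cc2N1C1CCCCC1`. In a functional assay on A-375 cells (Homo sapiens) for antiproliferative activity, read by MTT assay, with a stated time of 72 h (on this read-out higher numbers stand for weaker inhibition and lower numbers for stronger inhibition), compound 1 reaches only the limit of the assay, > 40000 nM, and no number is reported.
Compound 2, `COc1ccc(N2C(=O)COc3ccc(-c4cnc(Cl)c(NS(=O)(=O)c5ccc(F)cc5)c4)cc32)cc1`. In this assay compound 2 gives 32700 nM.
Compound 3, `COc1ccc(N2C(=O)COc3ccc(-c4cccc(NS(=O)(=O)c5ccc(F)cc5)c4)cc32)cc1`. In this assay compound 3 gives 38500 nM.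

All three measured compounds sit at the weak end of this assay. Compound 2 and compound 3 are within the scatter of each other, so no order between them can be drawn. How the core of compound 2 and the core of compound 3 differ is not broken down here.

Among the measured compounds shown here, the one counted change among the measured compounds is cyclohexyl in place of 4-methoxyphenyl on an amide-type nitrogen in a ring. It produced an at least 1.2-fold higher number from compound 2 to compound 1 (0.08 log units; that floor lies within the scatter); the step runs into (the limit of > 40000 nM in this assay, at which 1 of the 3 values shown sits), so only a floor for it is known.

Compound 4, `O=C1COc2ccc(-c3cccc(NS(=O)(=O)c4ccc(F)cc4)c3)cc2N1C1CCCCC1`, has not yet been measured. It differs from compound 3 by cyclohexyl in place of 4-methoxyphenyl on an amide-type nitrogen in a ring, which is the same change as that from compound 2 to compound 1, at the same place on the same kind of ring. Since compound 3 already gives 38500 nM, the step of a 1.3-fold higher number from compound 3 to compound 4 (0.11 log units; within the scatter) is expected to carry compound 4 further toward the weak end of the assay. The estimate for compound 4 is therefore 50000 nM, with a range from 30000 nM to 100000 nM, and it is likely that this assay reports only a limit for compound 4 rather than a number.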

Compound 4, half-maximal inhibitory concentration: 23800 nM
For compound 4 the middle estimate is 2.1-fold (0.32 log units) above the measured one; measured number below the stated range.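

In this assay, cyclohexyl in place of 4-methoxyphenyl on an amide-type nitrogen in a ring gives a 1.6-fold lower number from compound 3 to compound 4 (0.21 log units; within the scatter), so on the core of compound 3 this change does not move the result beyond the usual scatter of repeated measurements. Set beside the earlier case, the comparison of the two cores reads: the same change on two cores in this assay, an at least 1.2-fold higher number (0.08 log units; that floor lies within the scatter) from compound 2 to compound 1 and a 1.6-fold lower number (0.21 log units; within the scatter) from compound 3 to compound 4; the limit leaves it open whether they differ. This does not show that the change behaves alike on both cores, nor that it behaves differently, because only a floor is known for the step that ends at compound 1, whose value is a limit and not a number: the limit of > 40000 nM in this assay, at which 1 of the 4 values shown sits.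

The compounds shown leave open whether any other group on that amide-type nitrogen, such as a longer chain, a chain ending in an amine or one ending in a carboxylic acid, would give a result clearly apart from those of the 4-methoxyphenyl and cyclohexyl compounds. They also leave open whether the sulfonamide part, here always carrying the same 4-fluorophenyl group, could be replaced by another group, such as a pyridine ring or a morpholine, with any clear effect on the result in this assay.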